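Benzyloxy for neopentyloxy on the shared core

The source may hold more compounds than are shown below. What is called first, only, known or untested is meant among the compounds shown, and "the series" means these compounds.

Compound 3 `CC(C(=O)NCc1ccc(C(C)(C)C)cc1OCC(C)(C)C)c1ccc(NS(C)(=O)=O)c(F)c1` gives 3.8 nM in an assay on cells for antagonist activity at transient receptor potential cation channel subfamily V member 1 (Homo sapiens), read by FLIPR and calcium flux, with a stated time of 6 min (a higher number here means a weaker inhibitor, a lower number a stronger inhibitor), the highest of the three numbers in hand. Its nearest neighbour, compound 2 `CC(C)COc1cc(C(C)(C)C)ccc1CNC(=O)C(C)c1ccc(NS(C)(=O)=O)c(F)c1`, gives 2.1 nM; compound 1 `CCCCN(C)c1cc(C(C)(C)C)ccc1CNC(=O)C(C)c1ccc(NS(C)(=O)=O)c(F)c1` gives 1 nM. The steps among these three all lie in the group on the aromatic carbon: a 2.1-fold higher number from compound 1 to compound 2 (0.32 log units; beyond the scatter), a 3.8-fold higher number from compound 1 to compound 3 (0.58 log units; beyond the scatter), and a 1.8-fold higher number from compound 2 to compound 3 (0.26 log units; within the scatter).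

Compound 4 `CC(C(=O)NCc1ccc(C(C)(C)C)cc1OCc1ccccc1)c1ccc(NS(C)(=O)=O)c(F)c1` differs from compound 3 by phenyl in place of tert-butyl on a saturated chain carbon bound to an oxygen on an aromatic ring. Going by the values given here, no measured pair exchanges a tert-butyl for a phenyl, so the closest guide is the step from compound 2 to compound 3, which kept the number within the scatter when a methyl entered the same chain, and the two further steps from compound 1, which were modest. On that basis the step is expected to be small, in either direction, and likely not beyond the scatter: a 1.1-fold lower number from compound 3 to compound 4 (0.04 log units; within the scatter). Compound 4 is therefore expected to give 3.5 nM in this assay, within a range of 1 nM to 12 nM.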

Compound 4, inhibition constant: 2.9 nM
Compound 4: the middle estimate sits 1.2-fold (0.08 log units) above what was measured; the measured number falls inside the stated range.
By their numbers in this assay, from the lowest: compound 1; then compounds 2, 4 and 3 (each within the scatter of the next).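

In this assay, a phenyl ring is taken up at the end of the ether chain without a step beyond the scatter: phenyl in place of tert-butyl gives a 1.3-fold lower number from compound 3 to compound 4 (0.12 log units; within the scatter), and phenyl in place of isopropyl gives a 1.4-fold higher number from compound 2 to compound 4 (0.14 log units; within the scatter), so isobutoxy, neopentyloxy and benzyloxy cannot be told apart here. Benzyloxy, like the other two ethers, falls short of the butyl(methyl)amino group, with a 2.9-fold higher number from compound 1 to compound 4 (0.46 log units; beyond the scatter), and so the nitrogen-linked compound 1 stands apart from all three ethers. Nothing available explains either result.

The compounds shown leave open whether a shorter dialkylamine on the same aromatic carbon would match butyl(methyl)amino. They also leave open whether a chlorine or methoxy on the phenyl ring of the benzyloxy group would shift the number beyond the scatter.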